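This account rests on a few compounds, and the source may have more. Where it says the series, first, only, none or still open, it means among the compounds named here.

Working notes on the series, read in a functional assay on B16-F10 cells (Mus musculus) for antiproliferative activity, read by MTT assay, with a stated time of 48 h; on this read-out higher numbers stand for weaker inhibition and lower numbers for stronger inhibition. Compound 1 (`CC(=O)N1N=C(c2ccc3ccccc3c2)OC1c1ccccc1Br`) gives 6.98 ug/mL, and compound 2 (`CC(=O)N1N=C(c2ccc3ccccc3c2)OC1c1ccc(Br)cc1`) gives 4.68 ug/mL. Among the measured compounds shown here, these two values lie within the scatter of each other, so they set no order within the pair.

The next compound is compound 3 (`CC(=O)N1N=C(c2ccc3ccccc3c2)OC1c1ccccc1Cl`), with 2-chlorophenyl in place of 4-bromophenyl on a saturated ring carbon.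

For the measured compounds named here, the one measured step that bears on this change is a 1.5-fold lower number from compound 1 to compound 2 (0.17 log units; within the scatter), which relates 2-bromophenyl and 4-bromophenyl. Going by the values given here, no measured pair compares 2-chlorophenyl with 2-bromophenyl directly, so that part of the change remains open. No shift beyond the scatter is therefore expected in this assay. The estimated step is a 1.4-fold higher number from compound 2 to compound 3 (0.14 log units; within the scatter), and any direction in it is only tentative. For compound 3 the estimated value is 6.5 ug/mL, with an expected range of 3 ug/mL to 14 ug/mL.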

Compound 3, half-maximal inhibitory concentration: 4.93 ug/mL
The estimate for compound 3 lay 1.3-fold (0.12 log units) above the measured number; the range from low to high includes it.
By their numbers in this assay, from the lowest: compounds 2, 3 and 1 (each within the scatter of the next).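

In this assay, the change of chloro in place of bromo on an aromatic carbon can now be read directly, as a 1.4-fold lower number from compound 1 to compound 3 (0.15 log units; within the scatter) and so no shift is resolved between these two compounds. The other new step, a 1.1-fold higher number from compound 2 to compound 3 (0.02 log units; within the scatter) shows that 2-chlorophenyl and 4-bromophenyl on the saturated ring carbon are not told apart either, so all three compounds lie within the scatter of the next, with no order among them. No evidence on the cause of this result is available.

The compounds shown leave open whether a group other than a halogen on this phenyl ring, such as a methoxy or a dimethylamino group, would move the number beyond the scatter. Also open, going by these compounds, is how an unsubstituted phenyl would compare with these three compounds.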